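Swapping the Aryl Group on a Quinoline Thiosemicarbazone

The source may hold more compounds than are shown below. What is called first, only, known or untested is meant among the compounds shown, and "the series" means these compounds.

Compound 1, `Cc1ccccc1NC(=S)N/N=C/c1ccc2ccccc2n1`: 73200 nM
Compound 2, `CC(C)c1cccc(C(C)C)c1NC(=S)N/N=C/c1ccc2ccccc2n1`: 19500 nM
Compound 3, `CN(C)C(=S)N/N=C/c1ccc2cccnc2n1`: 560 nM

The three measured compounds were tested in a functional assay on HL-60 cells (Homo sapiens) for antiproliferative activity, read by sulforhodamine B assay, with a stated time of 72 h; on this read-out higher numbers stand for weaker inhibition and lower numbers for stronger inhibition. In this assay compound 1 gives 73200 nM, the highest of the three numbers, so it is the weakest inhibitor of the set. Its nearest neighbour is compound 2, which gives 19500 nM, a step beyond the usual scatter. Compound 3, which carries a different core, gives 560 nM and stands farthest from compound 1.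

Compound 4, `Fc1ccc(NC(=S)N/N=C/c2ccc3ccccc3n2)cc1`, has not yet been measured. It differs from compound 1 in one place: 4-fluorophenyl in place of 2-methylphenyl on an amide-type nitrogen. Among the compounds with values here, no measured pair shows this kind of exchange, so the size of the step is uncertain. Given that compound 1 sits at the weak end of the series, a small move toward a lower number is expected for compound 4, though it may not exceed the scatter; the step of a 1.8-fold lower number from compound 1 to compound 4 (0.26 log units; within the scatter) is this expected change. Compound 4 is therefore estimated at 40000 nM, with a range from 8000 nM to 150000 nM.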

Compound 4, half-maximal inhibitory concentration: 17000 nM
Beside the measured number, compound 4's estimate is 2.4-fold (0.37 log units) above it; measured number inside the range.
By their numbers in this assay, from the lowest: compound 3; then compounds 4 and 2 (each within the scatter of the next); then compound 1.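

In this assay, within the data shown here, this exchange shows for the first time that the group on the amide-type nitrogen can shift the number beyond the scatter: 4-fluorophenyl in place of 2-methylphenyl gives a 4.3-fold lower number from compound 1 to compound 4 (0.63 log units; beyond the scatter). The size of the group does not change in this exchange, as both groups hold 7 heavy atoms and one six-membered aromatic ring, so the step comes with a change in the group's substituent alone. No measurement shown here explains the step.

Because the methyl group leaves as the fluorine enters, the compounds shown cannot separate the contribution of each. Going by these compounds, it remains open how a plain phenyl, or a phenyl carrying an amine or a carboxylic acid, would behave at this nitrogen.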